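The compounds below may be only part of what the source reports. "The series", "measured", "known", "first", "only" and "open" are said of these compounds alone.

Compound 3 `O=C(O)Cc1sc(C(c2ccccc2)c2ccc(F)cc2)nc1-c1ccc(Cl)cc1` gives 17 nM in an in vitro assay on HEK385-7 cells for displacement of a labelled ligand from prostaglandin D2 receptor 2 (Homo sapiens) (a lower number here means a stronger inhibitor, a higher number a weaker inhibitor), the lowest of the three numbers measured. Compound 2 `O=C(O)Cc1sc(C(c2ccccc2)c2ccc(Cl)cc2)nc1-c1ccc(Cl)cc1` gives 45 nM and compound 1 `O=C(O)Cc1sc(C(Cc2ccccc2)c2ccccc2)nc1-c1ccc(Cl)cc1` gives 56 nM; the steps of a 2.6-fold lower number from compound 2 to compound 3 (0.42 log units; beyond the scatter) and a 3.3-fold lower number from compound 1 to compound 3 (0.52 log units; beyond the scatter) both exceed the usual scatter, so compound 3 is the strongest inhibitor of the three, whereas a 1.2-fold lower number from compound 1 to compound 2 (0.09 log units; within the scatter) stays within the scatter. Compound 4 `O=C(O)Cc1sc(C(c2ccc(F)cc2)c2ccc(F)cc2)nc1-c1ccc(Cl)cc1` differs from compound 3 by fluoro in place of hydrogen on an aromatic carbon, which read one bond further out is phenyl to 4-fluorophenyl. Within the data shown here, no measured step swaps hydrogen for fluoro directly; the nearest guides are a 2.6-fold lower number from compound 2 to compound 3 (0.42 log units; beyond the scatter) and a 3.3-fold lower number from compound 1 to compound 3 (0.52 log units; beyond the scatter), both modest and both ending at the fluorinated compound 3. On that basis compound 4 is expected to show a step of a 1.4-fold lower number from compound 3 to compound 4 (0.15 log units; within the scatter), a small move toward a lower number that may not clear the scatter. The estimate for compound 4 is therefore 12 nM, with a range from 5 nM to 30 nM.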

Compound 4, half-maximal inhibitory concentration: 9.7 nM
The estimate for compound 4 lay 1.2-fold (0.09 log units) above the measured number; low and high end bracket the measured number.
By their numbers in this assay, from the lowest: compounds 4 and 3 (each within the scatter of the next); then compounds 2 and 1 (each within the scatter of the next).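

In this assay, among these compounds, the step to the second 4-fluorophenyl is a 1.8-fold lower number from compound 3 to compound 4 (0.24 log units; within the scatter), and this is the first direct comparison of hydrogen with fluoro at this position. The earlier steps shown here compared fluoro only with chloro, or 4-fluorophenyl with benzyl, and left open whether the phenyl in compound 3 could carry a substituent at all; compound 4 shows that fluoro is accepted there without a change that clears the scatter. Nothing measured here accounts for this result.

The compounds shown leave open how larger or differently built groups at this same place, such as methoxy, trifluoromethyl or an amine, would read in this assay. They also do not show whether the tolerance for fluoro holds when the carboxylic acid sits on a longer chain.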